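The compounds below may be only part of what the source reports. "The series", "measured", "known", "first", "only" and "open" are said of these compounds alone.

In a functional assay on the whole organism (strain albino) for inhibition, with Rattus norvegicus as the target, read by paw edema, with stated times of 30 min and 5 h, at a dose of 100 mg/kg by the oral route (on this read-out lower numbers stand for less inhibition and higher numbers for more inhibition at the one dose given (going by the name of the read-out)), compound 1 `COc1ccc(/C=C/C(=O)c2ccc(NC(=O)CO[N+](=O)[O-])cc2)cc1` gives 46%, the highest of the three numbers measured. Compound 2 `COc1ccc(/C=C/C(=O)c2ccc(NC(=O)C(C)Br)cc2)cc1` gives 31% and compound 3 `COc1ccc(/C=C/C(=O)c2ccc(NC(=O)C(C)O[N+](=O)[O-])cc2)cc1` gives 35%; the step of a number 15 percentage points lower from compound 1 to compound 2 (beyond the scatter) and the step of a number 11 percentage points lower from compound 1 to compound 3 (beyond the scatter) both lie beyond the scatter, while the step of a number 4 percentage points higher from compound 2 to compound 3 (within the scatter) does not.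

Compound 4 `COc1ccc(/C=C/C(=O)c2ccc(NC(=O)COc3ccc(C(C)=O)cc3)cc2)cc1` differs from compound 1 by 4-acetylphenyl in place of nitro on an oxygen on a saturated carbon. For the measured compounds named here, two measured steps touch the same part of the molecule. The step of a number 4 percentage points higher from compound 2 to compound 3 (within the scatter) exchanges nitrooxy for bromo at that carbon and stays within the scatter, so the nitrooxy group as such does not stand out. The step of a number 15 percentage points lower from compound 1 to compound 2 (beyond the scatter) removes nitrooxy together with a further change and loses a modest amount. Going by the values given here, no measured compound carries a 4-acetylphenoxy group, so its effect is unknown. On this basis a small to modest decrease is expected for compound 4, with the step of a number 10 percentage points lower from compound 1 to compound 4 (within the scatter) the most likely outcome. The estimate for compound 4 in this assay is 36%, expected to lie between 22% and 50%.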

Compound 4, a percentage reported as inhibition, in the whole organism at one dose (the size of the read-out at that dose, not a potency): 30%
The estimate for compound 4 lay 6 percentage points above the measured number, and the stated range covers the measured number.
By their numbers in this assay, from the lowest: compounds 4, 2 and 3 (each within the scatter of the next); then compound 1.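

In this assay, the change from nitrooxy to 4-acetylphenoxy gives a number 16 percentage points lower from compound 1 to compound 4 (beyond the scatter), so the outcome at this oxygen does shift when a nitro is replaced by an aromatic group. The earlier exchange at the methyl-bearing carbon, a number 4 percentage points higher from compound 2 to compound 3 (within the scatter), had shown no such shift, although it involved a different replacement for nitrooxy and a different chain. No measurement shown here explains the lower number for compound 4.

For the compounds shown here, the single step cannot separate the loss of the nitro from the entry of the 4-acetylphenyl. A hydroxyl, a methoxy or an unsubstituted phenoxy on the same carbon would show whether the nitrooxy group of compound 1 matters in itself or whether the acetyl-bearing ring alone sets the number.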